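Nitro on the Benzyl Ring: From Compound 3 to Compound 4

The source may hold more compounds than are shown below. What is called first, only, known or untested is meant among the compounds shown, and "the series" means these compounds.

Three compounds share one core and were measured in a functional assay on SH-SY5Y cells (Homo sapiens) for antiproliferative activity, read by MTT assay, with a stated time of 72 h; on this read-out lower numbers stand for stronger inhibition and higher numbers for weaker inhibition:

compound 1 `c1ccc(COc2ccccc2Nc2ncnc3cc4c(cc23)OCCOCCO4)cc1` gives 93700 nM
compound 2 `c1ccc(COc2ccccc2Nc2ncnc3cc4c(cc23)OCCOCCOCCOCCO4)cc1` gives 24000 nM
compound 3 `c1ccc(COc2ccccc2Nc2ncnc3cc4c(cc23)OCCOCCOCCO4)cc1` gives 98400 nM

Compound 3 holds the highest number of the three. Its nearest neighbour is compound 1, whose value lies within the scatter of compound 3, so no order between those two can be read. Compound 2 stands further off, with a lower number that lies beyond the scatter.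

Compound 4 `O=[N+]([O-])c1ccc(COc2ccccc2Nc2ncnc3cc4c(cc23)OCCOCCOCCO4)cc1` differs from compound 3 in one place: nitro in place of hydrogen on an aromatic carbon. Among the compounds with values here, no measured pair shows this change, so its effect is not known from these data. The three measured compounds differ only in the length of the chain on the core, and none carries a substituent on the benzyl ring. Given that, the estimate for compound 4 assumes a step from compound 3 of a 1.2-fold lower number from compound 3 to compound 4 (0.06 log units; within the scatter), that is, no change beyond the scatter in this assay. Compound 4 is therefore expected to give about 85000 nM, with a range from 30000 nM to 250000 nM.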

Compound 4, half-maximal inhibitory concentration: 75500 nM
Beside the measured number, compound 4's estimate is 1.1-fold (0.05 log units) above it, and the stated range covers the measured number.
By their numbers in this assay, from the lowest: compound 2; then compounds 4, 1 and 3 (each within the scatter of the next).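

Within the data shown here, compound 4 is the first compound here with a substituent on the benzyl ring, and in this assay nitro in place of hydrogen on this aromatic carbon, para to a large group, gives a 1.3-fold lower number from compound 3 to compound 4 (0.12 log units; within the scatter). This position therefore accepts a nitro group, with its 3 heavy atoms and 2 hydrogen-bond acceptors, without a change that can be read in this assay. No other measurement bears on this result, and the data offer no explanation for it.

Going by these compounds, whether an amine or a carboxylic acid at the same place would leave the number equally unmoved remains open. Also open, on these data alone, is whether nitro on the benzyl ring would have the same outcome on the chains of compound 1 and compound 2.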